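Methyl-to-hydrogen change on a phenyl ring, one compound pending

A few compounds are considered here, and "the series" means these few. Any claim that something is new, unique, unknown or untested is made for them only; others in the source may bear on it.

Measured compounds:
Compound 1, `Cc1ccc(C2=NN(C3=NC(c4ccccc4)CS3)C(c3ccc4ccccc4c3)C2)cc1`, gives 8940 nM in a functional assay on BGC-823 cells (Homo sapiens) for inhibition, read by CCK-8 assay, with a stated time of 48 h; a higher number here means a weaker inhibitor, a lower number a stronger inhibitor.
Compound 2, `c1ccc(C2=NN(C3=NC(c4ccccc4)CS3)C(c3ccc4ccccc4c3)C2)cc1`, gives 9620 nM in this assay.
Compound 3, `Cc1ccc(C2=NN(C3=NC(c4ccccc4)CS3)C(c3cccc4ccccc34)C2)cc1C`, gives 8460 nM in this assay.

Compound 1 and compound 2 share a core; the change between them is hydrogen in place of methyl on an aromatic carbon, and in this assay the step reads a 1.1-fold higher number from compound 1 to compound 2 (0.03 log units; within the scatter). Compound 3 and compound 1 differ in more than one place, and the difference between the two cores is not broken down here. All three measured numbers lie within the scatter of one another, so no order among compound 1, compound 2 and compound 3 is claimed.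

Compound 4, `Cc1ccc(C2=NN(C3=NC(c4ccccc4)CS3)C(c3cccc4ccccc34)C2)cc1`, has not yet been measured. From compound 3 it differs by hydrogen in place of methyl on an aromatic carbon. This is the same kind of change as that from compound 1 to compound 2, not the same: the place is para to a large group in the one case, and ortho to a methyl group (1 heavy atom); meta to a large group in the other.

For compound 4 a step of a 1.1-fold higher number from compound 3 to compound 4 (0.03 log units; within the scatter) in this assay is expected, set beside the earlier step, because a 1.1-fold higher number from compound 1 to compound 2 (0.03 log units; within the scatter) lies within the scatter. Compound 4 is accordingly estimated at 9000 nM, expected between 5500 nM and 15000 nM.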

Compound 4, half-maximal inhibitory concentration: 13300 nM
The estimate for compound 4 lay 1.5-fold (0.17 log units) below the measured number; low and high end bracket the measured number.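

In this assay the new step reads a 1.6-fold higher number from compound 3 to compound 4 (0.20 log units; within the scatter), and naphthalen-1-yl in place of naphthalen-2-yl on a saturated ring carbon reads a 1.5-fold higher number from compound 1 to compound 4 (0.17 log units; within the scatter). Hydrogen in place of methyl on an aromatic carbon therefore gives two steps that cannot be told apart on these two cores: the same change on two cores in this assay, a 1.1-fold higher number (0.03 log units; within the scatter) from compound 1 to compound 2 and a 1.6-fold higher number (0.20 log units; within the scatter) from compound 3 to compound 4, 1.5-fold (0.16 log units) apart, within the scatter of two such steps. Going by these compounds alone, this shows no measurable disagreement between the cores for this change, but with only two pairs, each within the scatter, it does not show that the methyl group matters on either core or that the agreement would hold on a further core.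

The compounds shown leave open whether a group other than methyl or hydrogen at this place, such as an amine, a carboxylic acid or a longer chain, would shift the number beyond the scatter. Also open, on these data alone, is what a hydroxyl or a fluorine on the naphthalen-1-yl or naphthalen-2-yl group would do.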